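Swapping the amide tail of compound 2

This account rests on a few compounds, and the source may have more. Where it says the series, first, only, none or still open, it means among the compounds named here.

Compound 1 `Cn1ccc2ccc(-c3cc(Nc4ccccc4S(=O)(=O)Nc4cncnc4)cc4nccnc34)cc21`: > 100000 nM
Compound 2 `CN1CCC(NC(=O)c2ccncc2Nc2cc(-c3ccc4ccn(C)c4c3)c3nccnc3c2)CC1`: 19500 nM

In an assay on lysate for inhibition of 6-phosphofructo-2-kinase/fructose-2,6-bisphosphatase 3 (Homo sapiens), with stated times of 0.5 min and 45 min (on this read-out higher numbers stand for weaker inhibition and lower numbers for stronger inhibition), compound 1 gives > 100000 nM, which is a limit of the assay and not a number; it sits at the limit of > 100000 nM in this assay, at which 1 of the 2 values shown sits. In this assay, within the data shown here, compound 2 gives 19500 nM, the only numeric value shown, so no order between the two can be stated. Compound 3 `CC(=O)N1CCOC(CNC(=O)c2ccncc2Nc2cc(-c3ccc4ccn(C)c4c3)c3nccnc3c2)C1` differs from compound 2 by (4-acetylmorpholin-2-yl)methyl in place of 1-methylpiperidin-4-yl on an amide-type nitrogen. Among the measured compounds shown here, no measured step of this kind exists, so the step from compound 2 to compound 3 is expected to be a 1.8-fold higher number from compound 2 to compound 3 (0.25 log units; within the scatter), a small weakening that may stay within the scatter. Compound 3 is estimated at 35000 nM, ranging from 10000 nM to 100000 nM.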

Compound 3, half-maximal inhibitory concentration: > 100000 nM
Compound 3: a limit, no number (the forecaster's own chance of this, stated with the estimate: 30%); at least 2.8-fold (0.45 log units) between middle value and limit.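

In this assay, among these compounds, the result for compound 3 is a limit of the assay and not a number, yet it gives the first readable step at this amide-type nitrogen: an at least 5.1-fold higher number from compound 2 to compound 3 (0.70 log units; beyond the scatter). So this position does not accept every group, and (4-acetylmorpholin-2-yl)methyl loses inhibition relative to 1-methylpiperidin-4-yl. The true size of the step stays unknown, because the value sits at the assay's limit: the limit of > 100000 nM in this assay, at which 2 of the 3 values shown sit.

The change alters the ring, the acetyl group and the linking carbon all at once, so the responsible part cannot be singled out. As far as these compounds go, whether a morpholine without the acetyl, or a piperidine with a free ring amine, would do better remains open.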